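This account rests on a few compounds, and the source may have more. Where it says the series, first, only, none or still open, it means among the compounds named here.

Of the compounds shown here, three have been tested in a functional assay on HT-29 cells (Homo sapiens) for cytotoxicity, read by fluorescence and resazurin assay, with a stated time of 48 h (a lower number here means a stronger inhibitor, a higher number a weaker inhibitor), and a fourth awaits a reading. Compound 1 `COc1ccc(/C=C/c2cc(/C=C/c3ccc(OC)c(OC)c3)nc(OCCCCCCBr)n2)cc1OC` gives only a limit of the assay, > 20000 nM. Compound 2 `COc1ccc(/C=C/c2cc(/C=C/c3ccc(OC)c(OC)c3)nc(OCCCCCBr)n2)cc1OC` likewise reaches only a limit, > 20000 nM. Between them stands the change (bromo in place of bromomethyl on a saturated chain carbon, five bonds along the chain from an oxygen on an aromatic ring), and the step that the two limits leave unreadable from compound 1 to compound 2 cannot be sized from two limits. Compound 3 `BrCCCCCCOc1nc(/C=C/c2ccccc2)cc(/C=C/c2ccccc2)n1` also gives only a limit, > 20000 nM. How the core of compound 3 differs from the core of compound 1 is not broken down here. The not yet measured compound 4 `BrCCCCCOc1nc(/C=C/c2ccccc2)cc(/C=C/c2ccccc2)n1` carries the same change relative to compound 3, namely (bromo in place of bromomethyl on a saturated chain carbon, five bonds along the chain from an oxygen on an aromatic ring), so this change is made twice among the compounds shown. For the measured compounds named here, all three values so far sit at the limit of > 20000 nM in this assay, at which 3 of the 3 values shown sit, and a step from compound 3 that is expected to be a step that the limit leaves unreadable from compound 3 to compound 4 follows from that alone, since compound 2 showed nothing readable after the same change from compound 1. Compound 4 is therefore estimated at 30000 nM, between 12000 nM and 90000 nM, most likely again reported as a limit.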

Compound 4, half-maximal inhibitory concentration: > 20000 nM
Compound 4 ended at the assay's limit (the forecaster's own chance of this, stated with the estimate: 85%); the middle value lies beyond the limit too.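

Compound 3 and compound 4 both give only a limit, so the change from bromomethyl to bromo cannot be read between them, just as it could not be read between compound 1 and compound 2. The compounds shown leave open whether this change has any effect on either core, as every value is a limit: the limit of > 20000 nM in this assay, at which 4 of the 4 values shown sit.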